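The source may report more compounds than this note shows. Statements on the series, on what has been measured and on what is new or still open speak of the compounds shown alone.

Compound 1 `Cc1c(C(=O)Nc2c(F)cc(-c3cccc(F)c3)cc2F)nc2ccc(F)cc2c1O` gives 1.25% in a functional assay on Hep 3B2 cells (Homo sapiens) for antiproliferative activity, read by MTT assay, with a stated time of 24 h, tested at 0.05 ug/mL; on this read-out higher numbers stand for a stronger effect at the one concentration tested and lower numbers for a weaker effect.
Compound 2 `Cc1ccc2nc(C(=O)Nc3c(F)cc(-c4cccc(F)c4)cc3F)c(C)c(C(=O)O)c2c1` gives 2.11% in this assay.
Compound 3 `CCc1ccc2nc(C(=O)Nc3c(F)cc(-c4cccc(F)c4)cc3F)c(C)c(C(=O)O)c2c1` gives 0% in this assay.

All three measured compounds sit close to zero in this assay. Compound 3 has the lowest of the three numbers, yet its nearest neighbour is compound 1 and its furthest is compound 2, and both gaps lie within the scatter, so no ordering among them can be claimed.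

The next compound, compound 4 `Cc1c(C(=O)Nc2c(F)cc(-c3cccc(F)c3)cc2F)nc2ccc(F)cc2c1C(=O)O`, differs from compound 3 by fluoro in place of ethyl on an aromatic carbon. Within the data shown here, the one measured step touching that part of the shared core is a number 2.1 percentage points lower from compound 2 to compound 3 (within the scatter), which did not move the read-out beyond the scatter. Compound 1 also carries fluoro at that position, differing from compound 4 elsewhere, and in this assay compound 1 gives 1.25%. Nothing in these data points to a step beyond the scatter; compound 4 is therefore expected to stay near zero, with a number 1.5 percentage points higher from compound 3 to compound 4 (within the scatter) as the expected step. The estimate for compound 4 is 1.5%, from 0% to 6%.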

Compound 4, a percentage reported as inhibition, at one concentration (the size of the read-out at that concentration, not a potency): 0.05%
Beside the measured number, compound 4's estimate is 1.5 percentage points above it; measured number inside the range.
By their numbers in this assay, from the lowest: compounds 3, 4, 1 and 2 (each within the scatter of the next).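

Fluoro in place of ethyl on an aromatic carbon gives a number 0.1 percentage points higher from compound 3 to compound 4 (within the scatter) and fluoro in place of methyl at that carbon gives a number 2.1 percentage points lower from compound 2 to compound 4 (within the scatter) so with methyl, ethyl and fluoro now all seen there, the choice among these three groups does not move the number in this assay beyond the scatter. Among these compounds, the compounds also give a first reading at a second place, where carboxy in place of hydroxy on an aromatic carbon gives a number 1.2 percentage points lower from compound 1 to compound 4 (within the scatter) and that change likewise stays inside the scatter. No measurement at hand accounts for these numbers staying near zero.

With all four compounds near zero at the one concentration tested, these steps say little about either place. Going by these compounds, whether an amine on that aromatic carbon, or a primary amide in place of the carboxy, would lift the number remains open.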